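Swapping benzyl for cyclohexyl: cytotoxicity expected to stay low

The source may report more compounds than this note shows. Statements on the series, on what has been measured and on what is new or still open speak of the compounds shown alone.

Compound 1 `O=[N+]([O-])c1ccc(CSc2nnnn2C2CCCCC2)c([N+](=O)[O-])c1` and compound 2 `O=[N+]([O-])c1cc(CSc2nnnn2Cc2ccccc2)cc([N+](=O)[O-])c1` share a core and differ in the group on the aromatic nitrogen and in the placing of the nitro groups. In an ADME assay on Huh-7 cells (Homo sapiens) for cytotoxicity, read by MTT assay, with a stated time of 48 h (a lower number here means a stronger inhibitor, a higher number a weaker inhibitor), compound 1 gives only a limit, > 30000 nM, not a number. Compound 2 likewise reaches only a limit, > 30000 nM, in this assay. Compound 2 thus stands at the limit of > 30000 nM in this assay, at which 2 of the 2 values shown sit. Compound 3 `O=[N+]([O-])c1cc(CSc2nnnn2C2CCCCC2)cc([N+](=O)[O-])c1` differs from compound 2 by cyclohexyl in place of benzyl on an aromatic nitrogen. For the measured compounds named here, with no measured step for this change, the step from compound 2 to compound 3 is expected to be a step that the limit leaves unreadable from compound 2 to compound 3, nothing beyond the scatter. Compound 3 is therefore estimated at 40000 nM, between 20000 nM and 100000 nM.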

Compound 3, half-maximal inhibitory concentration: > 30000 nM
Compound 3 gave a limit, no number; the forecaster's own chance of this, stated with the estimate: 85%; the middle value lies beyond the limit too.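

Compound 2 and compound 3 both give only a limit in this assay, so the change from benzyl to cyclohexyl cannot be read as a step. The compounds shown leave open whether this swap alters cytotoxicity at all.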